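Removing one methyl from compound 3 in a flat series

This account rests on a few compounds, and the source may have more. Where it says the series, first, only, none or still open, it means among the compounds named here.

In a functional assay on MDA-MB-231 cells (Homo sapiens) for antiproliferative activity, read by MTT assay (a lower number here means a stronger inhibitor, a higher number a weaker inhibitor), compound 1 (`CC/C=C\C/C=C\C/C=C\CCCCCCCc1cc(=O)c2c(O)cc(O)cc2o1`) gives 6790 nM as its half-maximal inhibitory concentration. Compound 2 (`CCCCC/C=C\C/C=C\CCCCCCCc1cc(=O)c2c(O)cc(O)c(C)c2o1`) gives 6790 nM in the same read-out. Compound 3 (`CC/C=C\C/C=C\C/C=C\CCCCCCCc1cc(=O)c2c(O)c(C)c(O)c(C)c2o1`) gives 6790 nM and so stands level with both at the digits reported.

For the measured compounds named here, compound 4 (`CC/C=C\C/C=C\C/C=C\CCCCCCCc1cc(=O)c2c(O)cc(O)c(C)c2o1`) has no measurement yet. Its difference from compound 3 (hydrogen in place of methyl on an aromatic carbon) is hydrogen in place of methyl on an aromatic carbon, ortho to two hydroxy groups. Going by the values given here, no measured pair shows this change on its own, so the evidence for its size is indirect.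

No step beyond the scatter is expected in this assay in either direction. This expectation rests on compound 1 at 6790 nM and compound 3 at 6790 nM showing one value. The estimated no change at the digits printed from compound 3 to compound 4 (within the scatter) stays within the scatter. The estimate for compound 4 is 6790 nM with an expected range from 3400 nM to 13500 nM in this read-out.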

Compound 4, half-maximal inhibitory concentration: 6790 nM
Compound 4: the middle estimate sits on the measured number at the digits printed; measured number inside the range.
By their numbers in this assay, from the lowest: compounds 1, 2, 3 and 4 (each within the scatter of the next).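

In this assay, for the compounds shown here, hydrogen in place of methyl on an aromatic carbon, ortho to two hydroxy groups, gives no change at the digits printed from compound 3 to compound 4 (within the scatter), the first reading of this change on its own. Compound 4 also links the other two compounds through single changes: methyl in place of hydrogen on an aromatic carbon gives no change at the digits printed from compound 1 to compound 4 (within the scatter), and but-1-en-1-yl in place of butyl on a saturated chain carbon bound to a double-bonded chain carbon gives no change at the digits printed from compound 2 to compound 4 (within the scatter). All three single changes therefore read flat, and the methyl at this position is not needed to hold the value of compound 3 at 6790 nM.

As far as these compounds go, whether an amine, a carboxylic acid or an ethyl group on this aromatic carbon would shift the value remains open. Nothing available explains the flatness of these steps.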